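Working notes: nitro in place of methylsulfanyl

A few compounds are considered here, and "the series" means these few. Any claim that something is new, unique, unknown or untested is made for them only; others in the source may bear on it.

Of the compounds shown here, two have been measured in a functional assay on the whole organism with Rattus norvegicus as the target, at a dose of 20 mg/kg by the intraperitoneal route; on this read-out lower numbers stand for less inhibition and higher numbers for more inhibition at the one dose given (going by the name of the read-out). Compound 1 `Nc1nc(N)nc(-c2cccc(C(F)(F)F)c2)n1` carries a trifluoromethyl group on the six-membered aromatic ring of carbon only and gives 81%. Compound 2 `CSc1cccc(-c2nc(N)nc(N)n2)c1` carries methylsulfanyl at the same place and gives 49%, the lowest of the two numbers; the change was a number 32 percentage points lower from compound 1 to compound 2 (beyond the scatter).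

Compound 3 `Nc1nc(N)nc(-c2cccc([N+](=O)[O-])c2)n1` is not yet measured in this assay. Its difference from compound 2 is nitro in place of methylsulfanyl on an aromatic carbon.

Among the compounds with values here, the one measured step that bears on this change is the step into compound 2, where methylsulfanyl entered and the inhibition fell by a number 32 percentage points lower from compound 1 to compound 2 (beyond the scatter). Here methylsulfanyl leaves again, so the departure from the group with the lower number is shared, but no step with nitro entering has been measured, and the size of its effect is unknown. Within the data shown here, a rise in this assay is expected for compound 3, of the order of a number 16 percentage points higher from compound 2 to compound 3 (beyond the scatter), because compound 2 sits at 49% and the only other measured group, in compound 1, gives 81%. For compound 3 the estimate is 65%, with a range from 40% to 85%.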

Compound 3, a percentage reported as inhibition, in the whole organism at one dose (the size of the read-out at that dose, not a potency): 85%
Compound 3: the middle estimate sits 20 percentage points below what was measured; measured number inside the range.
By their numbers in this assay, from the lowest: compound 2; then compounds 1 and 3 (each within the scatter of the next).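

In this assay, putting nitro on this aromatic carbon in place of methylsulfanyl gives a number 36 percentage points higher from compound 2 to compound 3 (beyond the scatter), so the large drop seen on going to methylsulfanyl is now matched by a large rise on leaving it for a second, different group. Nitro in place of trifluoromethyl gives a number 4 percentage points higher from compound 1 to compound 3 (within the scatter), so at this place the read-out does not separate these two groups, although they share no atom, and among the three compounds methylsulfanyl alone stands apart. No measurement bears on why methylsulfanyl differs from the other two groups at this place.

The compounds shown leave open whether the lower number belongs to methylsulfanyl alone or extends to other sulfur-bearing groups such as methylsulfonyl, and whether an amine, a carboxylic acid or a nitrile on this carbon would stay with trifluoromethyl and nitro or fall with methylsulfanyl. Going by these compounds, with a single dose, it also remains open whether compound 1 and compound 3 would separate at a lower dose, and how the same groups behave elsewhere on the ring.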